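Three Aryl Swaps on the Shared Core, and a Fourth

The compounds below may be only part of what the source reports. "The series", "measured", "known", "first", "only" and "open" are said of these compounds alone.

Measured compounds:
compound 1 `CN(C)CCn1cnnc1-c1cc(Oc2ccc(NC(=O)N/N=C/c3ccccc3O[N+](=O)[O-])cc2F)ccn1`, 1270 nM
compound 2 `CN(C)CCn1cnnc1-c1cc(Oc2ccc(NC(=O)N/N=C/c3ccc(F)cc3F)cc2F)ccn1`, 1930 nM
compound 3 `CN(C)CCn1cnnc1-c1cc(Oc2ccc(NC(=O)N/N=C/c3cc(Br)c(O)c(Br)c3)cc2F)ccn1`, 3760 nM

In a functional assay on NCI-H460 cells (Homo sapiens) for cytotoxicity, read by MTT assay, with a stated time of 72 h (a lower number here means a stronger inhibitor, a higher number a weaker inhibitor), compound 3 gives the highest of the three numbers; it lies within the scatter of compound 2 and beyond it only against compound 1, as the step of a 3.0-fold higher number from compound 1 to compound 3 (0.47 log units; beyond the scatter) shows. Compound 4 `CN(C)CCn1cnnc1-c1cc(Oc2ccc(NC(=O)N/N=C/c3ccc(O)cc3O)cc2F)ccn1` differs from compound 3 in one place: 2,4-dihydroxyphenyl in place of 3,5-dibromo-4-hydroxyphenyl on a carbon with a double bond to nitrogen. All three measured steps swap the same aryl group, and they were small: a 1.5-fold higher number from compound 1 to compound 2 (0.18 log units; within the scatter) and a 1.9-fold higher number from compound 2 to compound 3 (0.29 log units; within the scatter) stayed within the scatter, a 3.0-fold higher number from compound 1 to compound 3 (0.47 log units; beyond the scatter) was modest. Within the data shown here, no measured step involves a 2,4-dihydroxyphenyl, so the expectation rests on this narrow spread. A step within the scatter, a 1.4-fold lower number from compound 3 to compound 4 (0.16 log units; within the scatter), is therefore expected. Compound 4 is estimated at 2600 nM in this assay, with a range from 1000 nM to 6500 nM.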

Compound 4, half-maximal inhibitory concentration: 11300 nM
Beside the measured number, compound 4's estimate is 4.3-fold (0.64 log units) below it, outside the stated range (above it).
By their numbers in this assay, from the lowest: compounds 1, 2 and 3 (each within the scatter of the next, the first and the last beyond it); then compound 4.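

At this position on a carbon with a double bond to nitrogen, the aryl swap can matter more than the first three compounds suggested: 2,4-dihydroxyphenyl gives a 3.0-fold higher number from compound 3 to compound 4 (0.48 log units; beyond the scatter) and a 5.9-fold higher number from compound 2 to compound 4 (0.77 log units; beyond the scatter) and also an 8.9-fold higher number from compound 1 to compound 4 (0.95 log units; beyond the scatter) in this assay. Compound 3 also carries a hydroxyl on its ring, so having a hydroxyl does not by itself set the number. No evidence here explains the rise. Still open, going by these compounds, is which of the two hydroxyls in compound 4 accounts for the higher number, and how a methoxy group or an amine in their place would read.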